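Trifluoromethoxy for methoxy in a quinolinone amine series

This account rests on a few compounds, and the source may have more. Where it says the series, first, only, none or still open, it means among the compounds named here.

Compound 1 `COc1ccc(C(C)N(Cc2ccc(C(C)(C)C)cc2)Cc2cc3cc(C4CC4)ccc3[nH]c2=O)cc1Cl`, compound 2 `CC(c1ccc(OC(F)(F)F)c(Cl)c1)N(Cc1ccc(C(C)(C)C)cc1)Cc1cc2cc(C3CC3)ccc2[nH]c1=O` and compound 3 `COc1ccc([C@H](C)N(Cc2ccc(C(C)(C)C)cc2)Cc2cc3cc(C4CC4)ccc3[nH]c2=O)cc1` share one core; compound 4 `C[C@@H](c1ccc(OC(F)(F)F)cc1)N(Cc1ccc(C(C)(C)C)cc1)Cc1cc2cc(C3CC3)ccc2[nH]c1=O` is not yet measured. In a toxicity assay on MDCK cells (Canis lupus familiaris) for cytotoxicity, read by crystal violet staining, with a stated time of 48 h (on this read-out higher numbers stand for lower toxicity in this test and lower numbers for higher toxicity in this test), compound 1 gives a limit of > 10000 nM. In this assay compound 2 gives a limit of > 10000 nM. In this assay compound 3 gives a limit of > 10000 nM. The change trifluoromethyl in place of methyl on an oxygen on an aromatic ring therefore gives a step that the two limits leave unreadable from compound 1 to compound 2. The two cores differ by 1-(4-methoxyphenyl)ethyl in place of 1-(3-chloro-4-methoxyphenyl)ethyl on an amine nitrogen, with a step that the two limits leave unreadable from compound 1 to compound 3. The change trifluoromethyl in place of methyl on an oxygen on an aromatic ring is the same change, made on the same place. The expected step is a step that the limit leaves unreadable from compound 3 to compound 4, beside a step that the two limits leave unreadable from compound 1 to compound 2, which rests on (the limit of > 10000 nM in this assay, at which 3 of the 3 values shown sit). Compound 4 is expected at 15000 nM, from 7000 nM to 50000 nM.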

Compound 4, half-maximal cytotoxic concentration: > 10000 nM
Compound 4 gave a limit, no number; the forecaster's own chance of this, stated with the estimate: 85%; the middle value lies beyond the limit too.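

Compound 3 and compound 4 both give only limits in this assay, so the step between them, methoxy to trifluoromethoxy, cannot be read. The compounds shown leave open whether this change alters the half-maximal cytotoxic concentration at all: the limit of > 10000 nM in this assay, at which 4 of the 4 values shown sit.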